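Two aryl groups, one unmeasured analogue, one estimate

The compounds below may be only part of what the source reports. "The series", "measured", "known", "first", "only" and "open" are said of these compounds alone.

Measured compounds:
- compound 1, `O=C(Nc1ccc(Oc2ccnc3[nH]ccc23)cc1)c1cc2cccnc2n(-c2ccc(Cl)cc2)c1=O`: 290 nM
- compound 2, `O=C(Nc1ccc(Oc2ccnc3[nH]ccc23)c(F)c1)c1cc2cccnc2n(-c2ccc(F)cc2)c1=O`: 87 nM
- compound 3, `O=C(Nc1ccc(Oc2ccnc3[nH]ccc23)c(F)c1)c1cc2cccnc2n(-c2ccc(Cl)cc2)c1=O`: "not determined" (no result reported)

The three measured compounds share one core and differ in the aryl group on the aromatic nitrogen and in a single fluorine on the ring bearing the amide. In a functional assay on NCI-H460 cells (Homo sapiens) for antiproliferative activity, read by MTT assay, with a stated time of 72 h (a higher number here means a weaker inhibitor, a lower number a stronger inhibitor), compound 1 gives 290 nM. Compound 2, which carries the fluorine on the amide-bearing ring and a 4-fluorophenyl on the nitrogen, gives 87 nM in this assay. Compound 3 combines the fluorinated amide ring of compound 2 with the 4-chlorophenyl of compound 1, but in this assay compound 3 gives only "not determined" (no result reported); where it stands can only be bracketed by the values of compound 1 and compound 2.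

The step to compound 4, `O=C(Nc1ccc(Oc2ccnc3[nH]ccc23)c(F)c1)c1cc2cccnc2n(-c2ccc(F)c(Cl)c2)c1=O`, is 3-chloro-4-fluorophenyl in place of 4-chlorophenyl on an aromatic nitrogen. Going by the values given here, no measured pair shows this change, so its size and direction are unknown; a step that stays within the scatter is as plausible as a modest shift either way. Since the two measured values lie within a narrow band, compound 4 is expected to land near the middle of that band, at about 130 nM, with a range of 40 nM to 450 nM.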

Compound 4, half-maximal inhibitory concentration: 1050 nM
Compound 4: the middle estimate sits 8.1-fold (0.91 log units) below what was measured; the whole stated range lies below it.
By their numbers in this assay, from the lowest: compound 2; then compound 1; then compound 4.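

In this assay, going by these compounds alone, the addition of one chlorine to the 4-fluorophenyl on the aromatic nitrogen gives a 12-fold higher number from compound 2 to compound 4 (1.08 log units; beyond the scatter) and so provides the first comparison here of two compounds that differ in one place, since compound 1 and compound 2 differ in both the aryl group and the fluorine on the amide-bearing ring. With that fluorinated ring held constant, the step shows that this aryl group does not tolerate every change: chloro in place of hydrogen on an aromatic carbon, turning 4-fluorophenyl into 3-chloro-4-fluorophenyl, is enough to give a clearly weaker antiproliferative result. Nothing available explains why this single substitution has so large an effect.

Going by these compounds, compound 3 has no number, so the step from it to compound 4 cannot be read, and the effect of adding fluorine to the 4-chlorophenyl remains unknown. On these data alone, it also remains open whether a methyl or a methoxy group in place of this chlorine would give a similar loss, or whether the loss is particular to chlorine.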